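Working notes: from compound 3 to compound 4

The source may hold more compounds than are shown below. What is called first, only, known or untested is meant among the compounds shown, and "the series" means these compounds.

compound 1 `CC(=O)N1CCN(c2cccc(-c3cc(-c4ccnn4C4CC4)c4c(N)ncnn34)c2)C(=O)C1(C)C` - 36 nm/s
compound 2 `CC(=O)N1CCN(c2cccc(-c3cc(-c4cc(C(C)C)no4)c4c(N)ncnn34)c2)C(=O)C1(C)C` - "not determined" (no result reported)
compound 3 `CC(=O)N1CCN(c2cc(-c3cc(Cl)c4c(N)ncnn34)ccc2C(F)(F)F)C(=O)C1(C)C` - 150 nm/s

In an ADME assay on Caco-2 cells (Homo sapiens) for permeability, in the apical to basolateral direction (on this read-out lower numbers stand for lower permeability and higher numbers for higher permeability), compound 3 stands highest of the two numbers at 150 nm/s. Compound 1 gives 36 nm/s, and the gap between these two compounds lies beyond the scatter. Compound 2 offers no number for comparison. Compound 4 `COc1ccc(-c2cc(Cl)c3c(N)ncnn23)cc1N1CCN(C(C)=O)C(C)(C)C1=O` has methoxy in place of trifluoromethyl on an aromatic carbon. Going by the values given here, no measured pair differs in one place, so this change has no direct precedent in this assay. A small fall, not beyond the scatter, is expected from the starting point of compound 3 at 150 nm/s. The expected change is a 1.4-fold lower number from compound 3 to compound 4 (0.13 log units; within the scatter). Compound 4 is estimated at 110 nm/s, within an expected range of 45 nm/s to 260 nm/s.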

Compound 4, apparent permeability: 170 nm/s
For compound 4 the middle estimate is 1.5-fold (0.19 log units) below the measured one, within the range that was stated.
By their numbers in this assay, from the lowest: compound 1; then compounds 3 and 4 (each within the scatter of the next).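

In this assay, going by these compounds alone, methoxy in place of trifluoromethyl, ortho to a large group and para to a large group, gives the first single-place step, and it lies within the scatter (a 1.1-fold higher number from compound 3 to compound 4 (0.05 log units; within the scatter)). At this position, exchanging these two groups therefore produces no readable difference, even though methoxy brings a hydrogen-bond acceptor and fewer heavy atoms. No available evidence bears on the result.

As far as these compounds go, whether an amine or a carboxylic acid at this position would also stay within the scatter remains open. So does whether the same exchange would read alike with a group other than chlorine on the shared core.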